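The compounds below may be only part of what the source reports. "The series", "measured", "known", "first", "only" and "open" are said of these compounds alone.

Of the compounds shown here, three have been tested so far in an assay on HEK293 cells for inhibition of Lysophosphatidylserine lipase ABHD12 (Homo sapiens), read by scintillation counting, with stated times of 30 min and 5 min; on this read-out higher numbers stand for weaker inhibition and lower numbers for stronger inhibition. Compound 1 `Cc1c(Br)cc(C(=O)NC2CCNCC2)c(=O)n1Cc1ccc(F)cc1` gives only a limit of the assay, > 10000 nM. Compound 2 `Cc1c(Cl)cc(C(=O)NC2CCCCCC2)c(=O)n1Cc1ccc(F)cc1` likewise gives only a limit, > 10000 nM. Compound 3 `Cc1ccc(C(=O)NC2CCCCCC2)c(OCc2ccc(F)cc2)n1` also gives only a limit, > 10000 nM. Compound 3 therefore stands at the limit of > 10000 nM in this assay, at which 3 of the 3 values shown sit, with no real number of its own. Compound 4 `Cc1nc(OCc2ccc(F)cc2)c(C(=O)NC2CCCCCC2)cc1-c1ccc(F)cc1` differs from compound 3 in one place: 4-fluorophenyl in place of hydrogen on an aromatic carbon. Going by the values given here, no two measured compounds differ in a single place, so nothing measured shows what such a change does. In this assay the expected step is an at least 1.4-fold lower number from compound 3 to compound 4 (0.15 log units; that floor lies within the scatter), a modest gain toward stronger inhibition, with the limit still quite possible. For compound 4 the estimate in this assay is 7000 nM, within a range from 1500 nM to 30000 nM.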

Compound 4, half-maximal inhibitory concentration: > 10000 nM
Compound 4 ended at the assay's limit; the forecaster's own chance of this, stated with the estimate: 55%; at least 1.4-fold (0.15 log units) between middle value and limit.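

No step can be read from compound 3 to compound 4, because both give only a limit: the limit of > 10000 nM in this assay, at which 4 of the 4 values shown sit. On these data alone, what 4-fluorophenyl in place of hydrogen does to inhibition stays open, as does whether any related compound gives a real number.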